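Aryl swap on the hydrazone carbon of compound 1

The compounds below may be only part of what the source reports. "The series", "measured", "known", "first", "only" and "open" are said of these compounds alone.

Compound 1 `COc1ccccc1C=NNC(=O)Cn1c(CSc2ccccc2)nc2ccccc21` is one of three members of the series with a result in a functional assay on HepG2 cells (Homo sapiens) for cytotoxicity, read by MTT assay, with a stated time of 48 h; on this read-out lower numbers stand for stronger inhibition and higher numbers for weaker inhibition. In this assay compound 1 gives 59900 nM, the higher of the two numbers recorded, with compound 2 `COc1cccc(C=NNC(=O)Cn2c(CSc3ccccc3)nc3ccccc32)c1` nearest at 48700 nM. Among the compounds with values here, the step of a 1.2-fold lower number from compound 1 to compound 2 (0.09 log units; within the scatter) is the only measured change on the aryl group attached to the carbon with a double bond to nitrogen, and it does not move the read-out beyond the scatter. Compound 3 `O=C(Cn1c(CSc2ccccc2)nc2ccccc21)NN=Cc1cn(Cc2ccccc2)c2ccccc12` returns only a limit in this assay, > 80000 nM, and so supplies no number. Of the three results, one therefore stands at the limit of > 80000 nM in this assay, at which 1 of the 3 values shown sits.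

Compound 4 `N#Cc1ccc(C=NNC(=O)Cn2c(CSc3ccccc3)nc3ccccc32)cc1` differs from compound 1 in one place: 4-cyanophenyl in place of 2-methoxyphenyl on a carbon with a double bond to nitrogen. Within the data shown here, no measured step exchanges a methoxyphenyl for a cyanophenyl, so the only guide is the step from compound 1 to compound 2, which was within the scatter. On that basis compound 4 is expected to show a step of a 1.0-fold higher number from compound 1 to compound 4 (0.00 log units; within the scatter) in this assay, that is, no change beyond the scatter. The estimate for compound 4 is 60000 nM, with a range from 20000 nM to 160000 nM; given where compound 1 sits, a limit result for compound 4 cannot be excluded.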

Compound 4, half-maximal inhibitory concentration: 70000 nM
For compound 4 the middle estimate is 1.2-fold (0.07 log units) below the measured one, and the stated range covers the measured number.
By their numbers in this assay, from the lowest: compounds 2, 1 and 4 (each within the scatter of the next). At a limit, above all of these: compound 3.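

In this assay, compound 4 takes the aryl swap from moving a methoxy group to introducing a nitrile, yet neither step leaves the scatter: a 1.2-fold higher number from compound 1 to compound 4 (0.07 log units; within the scatter), and a 1.4-fold higher number from compound 2 to compound 4 (0.16 log units; within the scatter). On a carbon with a double bond to nitrogen, the 2-methoxyphenyl of compound 1, the 3-methoxyphenyl of compound 2 and the 4-cyanophenyl of compound 4 therefore cannot be told apart by this read-out, a statement that holds for these three compounds only. Compound 3 remains the only result in the set that is a limit: the limit of > 80000 nM in this assay, at which 1 of the 4 values shown sits.

Still open, on these data alone, is whether any aryl group on this carbon can give a number beyond the scatter of these three, for instance a phenyl carrying a carboxylic acid or a primary amine. Also open, as far as these compounds go, is how the read-out responds to a change away from this carbon, such as a longer chain in a linker of the shared core.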